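This account rests on a few compounds, and the source may have more. Where it says the series, first, only, none or still open, it means among the compounds named here.

Measured compounds:
Compound 1 `N#CC1=C(N)Oc2c(c3nc4ccccc4nc3c3ccccc23)C12C(=O)N(Cc1cnnn1-c1ccc(Cl)cc1)c1ccccc12`: > 50000 nM
Compound 2 `N#CC1=C(N)Oc2c(c3nc4ccccc4nc3c3ccccc23)C12C(=O)N(Cc1cnnn1-c1cccc(Cl)c1)c1ccccc12`: 43600 nM

Within the data shown here, in a functional assay on MCF7 cells (Homo sapiens) for antiproliferative activity, read by MTT assay, with a stated time of 48 h (on this read-out lower numbers stand for stronger inhibition and higher numbers for weaker inhibition), compound 2 gives 43600 nM, the only number among the two values shown. Compound 1 reaches only a limit of the assay, > 50000 nM. The step of an at least 1.1-fold lower number from compound 1 to compound 2 (0.05 log units; that floor lies within the scatter) is known only as a floor that lies within the scatter. Compound 3 `N#CC1=C(N)Oc2c(c3nc4ccccc4nc3c3ccccc23)C12C(=O)N(Cc1cnnn1-c1cc(Cl)ccc1Cl)c1ccccc12` differs from compound 2 by chloro in place of hydrogen on an aromatic carbon, which one bond further out reads as 3-chlorophenyl to 2,5-dichlorophenyl. Among the measured compounds shown here, no measured step adds a chloro group, so no step beyond the scatter is expected in this assay. Compound 3 is estimated at 40000 nM, between 15000 nM and 100000 nM, an expected step of a 1.1-fold lower number from compound 2 to compound 3 (0.04 log units; within the scatter).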

Compound 3, half-maximal inhibitory concentration: > 50000 nM
Compound 3: a limit, no number (the forecaster's own chance of this, stated with the estimate: 35%); middle value at least 1.2-fold (0.09 log units) away from the limit.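

In this assay, putting a chloro group on the ring carbon ortho to a large group and para to a chloro group gives an at least 1.1-fold higher number from compound 2 to compound 3 (0.05 log units; that floor lies within the scatter). As far as these compounds go, the value of compound 3 is a limit, so the true size of this step stays unknown, and a second chloro group on this ring shows no sign of stronger inhibition. The step between compound 1 and compound 3 cannot be read, because both stand at one limit: the limit of > 50000 nM in this assay, at which 2 of the 3 values shown sit.

From the compounds shown here alone, whether an amine or a methoxy group on this ring would give a clearly lower number remains open.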